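Saturating the acid-bearing chain of compound 1

The source may report more compounds than this note shows. Statements on the series, on what has been measured and on what is new or still open speak of the compounds shown alone.

Compound 1 `O=C(O)/C=C/c1ccc(Cn2cccn2)cc1OCCc1ccc2ccccc2c1` is the stronger of the two measured compounds: in an assay on CHO cells for displacement of a labelled ligand from prostaglandin E2 receptor EP3 subtype (Mus musculus), read by scintillation counting (on this read-out lower numbers stand for stronger inhibition and higher numbers for weaker inhibition), compound 1 gives 12 nM, while its nearest neighbour, compound 2 `O=C(O)/C=C/c1ccc(COc2ccccc2)cc1OCCc1ccc2ccccc2c1`, gives 130 nM in this assay. Going by the values given here, the one measured step, an 11-fold higher number from compound 1 to compound 2 (1.03 log units; beyond the scatter), concerns the group on the saturated chain carbon bound to an aromatic carbon and says nothing about the acid-bearing chain. Compound 3 `O=C(O)CCCc1ccc(Cn2cccn2)cc1OCCc1ccc2ccccc2c1` differs from compound 1 elsewhere: 3-carboxypropyl in place of 2-carboxyethenyl on an aromatic carbon. Among the compounds with values here, no measured step bears on this change, so the expectation rests on compound 1 alone at 12 nM and on the change being confined to the chain carrying the acid on the shared core. A modest weakening is expected, a 3.3-fold higher number from compound 1 to compound 3 (0.52 log units; beyond the scatter), close to the edge of the scatter. Compound 3 is therefore estimated at 40 nM in this assay, with a range from 10 nM to 200 nM.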

Compound 3, inhibition constant: 39 nM
For compound 3 the middle estimate is 1.0-fold (0.01 log units) above the measured one; low and high end bracket the measured number.
By their numbers in this assay, from the lowest: compound 1; then compound 3; then compound 2.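

At the aromatic carbon para to the (1H-pyrazol-1-yl)methyl group, 3-carboxypropyl in place of 2-carboxyethenyl gives a 3.3-fold higher number from compound 1 to compound 3 (0.51 log units; beyond the scatter) in this assay. This position therefore accepts a chain with one double bond fewer and one more heavy atom, at a modest cost in this read-out. The 2-carboxyethenyl group is thus not required for measurable inhibition, although compound 1 keeps the lower number.

Going by these compounds, the step changes chain length and saturation together, so the share of each stays open; a 2-carboxyethyl chain would separate the two, and an amide or a tetrazole in place of the carboxylic acid would test the acid itself. Nothing available accounts for the size of this step.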